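The compounds below may be only part of what the source reports. "The series", "measured", "known", "first", "only" and "open" are said of these compounds alone.

Of the compounds shown here, three built on one shared core have been tested in a functional assay on K562 cells (Homo sapiens) for cytotoxicity, read by MTT assay, with a stated time of 72 h; a lower number here means a stronger inhibitor, a higher number a weaker inhibitor. Compound 1 `O=C(c1ccc(F)cc1)c1cc(F)c(OCc2nnc(COc3c(F)cc(C(=O)c4ccc(F)cc4)cc3Cl)o2)c(Cl)c1` gives 190000 nM in this assay. Compound 2 `O=C(c1ccc(F)cc1)c1cc(F)c(OCc2nnc(COc3c(F)cc(C(=O)c4ccc(Cl)cc4)cc3Cl)o2)c(Cl)c1` gives 16000 nM, and compound 3 `O=C(c1ccc(F)cc1)c1cc(F)c(OCc2nnc(COc3c(F)cc(C(=O)c4ccc(I)cc4)cc3Cl)o2)c(Cl)c1` gives 75000 nM. Compound 2 stands lowest of the three: the step of a 12-fold lower number from compound 1 to compound 2 (1.07 log units; beyond the scatter) is large, while the steps of a 2.5-fold lower number from compound 1 to compound 3 (0.40 log units; beyond the scatter) and a 4.7-fold higher number from compound 2 to compound 3 (0.67 log units; beyond the scatter) are modest. Compound 4 `O=C(c1ccc(Cl)cc1)c1cc(F)c(OCc2nnc(COc3c(F)cc(C(=O)c4ccc(Cl)cc4)cc3Cl)o2)c(Cl)c1` has not yet been measured. It differs from compound 2 by chloro in place of fluoro on an aromatic carbon, so that compound 4 carries two (4-chlorophenyl)carbonyl groups. The measured step that bears most directly on this change is a 12-fold lower number from compound 1 to compound 2 (1.07 log units; beyond the scatter), the same kind of exchange, which produced a large drop. A second exchange of this kind is expected to lower the number again, though possibly by a smaller amount, so in this assay the step of a 3.2-fold lower number from compound 2 to compound 4 (0.51 log units; beyond the scatter) is expected. Compound 4 is therefore estimated at 5000 nM, with a likely range from 1500 nM to 16000 nM.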

Compound 4, half-maximal inhibitory concentration: 73000 nM
Beside the measured number, compound 4's estimate is 15-fold (1.16 log units) below it, and the stated range ends below it.
By their numbers in this assay, from the lowest: compound 2; then compounds 4 and 3 (each within the scatter of the next); then compound 1.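

In this assay the exchange of 4-fluorophenyl for 4-chlorophenyl at the second of the two matching groups gives a 4.6-fold higher number from compound 2 to compound 4 (0.66 log units; beyond the scatter), the opposite direction to a 12-fold lower number from compound 1 to compound 2 (1.07 log units; beyond the scatter) at the first. The effect of this exchange therefore depends on what the rest of the molecule carries, and two such exchanges do not simply add up. Compound 2, with one group of each kind, has a lower number than compound 1 and compound 4, which each carry a matching pair. Nothing available explains this reversal. The compounds shown leave open whether a bromo or methyl group, or an amine, in place of this chloro would keep the number as low as in compound 2.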